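Swapping a chlorinated hydrazone arm for a methylated one

The source may hold more compounds than are shown below. What is called first, only, known or untested is meant among the compounds shown, and "the series" means these compounds.

Of the compounds shown here, two of a shared core have so far been tested in a functional assay on MCF7 cells (Homo sapiens) for cytotoxicity, read by sulforhodamine B assay; on this read-out lower numbers stand for stronger inhibition of growth and higher numbers for weaker inhibition of growth. Compound 1 `CC1=CC[C@@H]([C@@](C)(O)CCCC(C)(C)NC(=S)N/N=C\c2ccccc2)CC1` gives 7720 nM in this assay. Compound 2 `CC1=CC[C@@H]([C@@](C)(O)CCCC(C)(C)NC(=S)N/N=C\c2ccccc2Cl)CC1`, which carries a chloro in place of hydrogen on an aromatic carbon, gives 31200 nM in this assay, the higher of the two numbers; the step of a 4.0-fold higher number from compound 1 to compound 2 (0.61 log units; beyond the scatter) lies beyond the scatter, so compound 2 inhibits growth more weakly than compound 1.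

Compound 3 `CC1=CC[C@@H]([C@@](C)(O)CCCC(C)(C)NC(=S)N/N=C(/C)c2ccccc2)CC1` has not yet been measured. Compared with compound 2 it differs by a group of 9 heavy atoms (8 carbon, 1 nitrogen; one six-membered aromatic ring of carbon only) in place of a group of 9 heavy atoms (7 carbon, 1 nitrogen, 1 chlorine; one six-membered aromatic ring of carbon only), on an amide-type nitrogen. The chlorine is gone, and the imine carbon now carries a methyl. Among the compounds with values here, only one measured step bears on this change: from compound 1 to compound 2, adding the chloro raised the number, so taking it away is expected to lower the number again, while the added methyl has no measured precedent here. In this assay compound 3 is therefore estimated to give 9000 nM, within a range from 3000 nM to 30000 nM. This expectation corresponds to a step of a 3.5-fold lower number from compound 2 to compound 3 (0.54 log units; beyond the scatter).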

Compound 3, concentration for 50% growth inhibition: 23600 nM
The estimate for compound 3 lay 2.6-fold (0.42 log units) below the measured number, and the stated range covers the measured number.
By their numbers in this assay, from the lowest: compound 1; then compounds 3 and 2 (each within the scatter of the next).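

Within this assay, the methylated arm on the amide-type nitrogen gives a 3.1-fold higher number from compound 1 to compound 3 (0.49 log units; beyond the scatter) and so inhibits growth more weakly than the unsubstituted arm of compound 1, which shows that the ring chloro is not the only change to this group that can weaken the effect. Set against the chlorinated arm, the same group gives a 1.3-fold lower number from compound 2 to compound 3 (0.12 log units; within the scatter), so the methyl and the chloro, although they are different additions to the arm of compound 1, cannot be told apart here, and the first three compounds offer no exception to the finding that each addition raises the number. Nothing measured on these compounds explains why either addition has this effect.

These three compounds do not show whether the rise depends on the particular atoms added or would also follow from other additions to the arm, such as a methoxy group on the aromatic ring or an ethyl group in place of the methyl. They also leave open what an amine or a carboxylic acid on the aromatic ring would do, and whether any addition to this arm could bring the number below that of compound 1.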